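Ester to Amide on the Side Chain: Half-Life Expectation

This account rests on a few compounds, and the source may have more. Where it says the series, first, only, none or still open, it means among the compounds named here.

Compound 1 `CCOC(=O)/C=C/c1ccc(NC(=O)C2(NC(=O)c3ccc4c(C5CCCC5)c(-c5ncc(Cl)cn5)n(C)c4c3)CCC2)cc1OCC`: > 5 h
Compound 2 `CCOc1cc(NC(=O)C2(NC(=O)c3ccc4c(C5CCCC5)c(-c5ncc(Cl)cn5)n(C)c4c3)CCC2)ccc1/C=C/C(=O)OCC(=O)OC`: 2.1 h

In an ADME assay (liver) for pharmacokinetics, with Liver microsome (Homo sapiens) as the target, using microsomes (a higher number here means that the compound lasts longer, a lower number that the compound disappears faster), compound 1 reaches only a limit, > 5 h. Within the data shown here, compound 2 gives 2.1 h, the one number in this set. Among the measured compounds shown here, the measured step of an at least 2.3-fold lower number from compound 1 to compound 2 (0.37 log units; beyond the scatter) is the only guide, and it concerns a different change on the same chain. Compound 3 `CCCN(C)C(=O)COC(=O)/C=C/c1ccc(NC(=O)C2(NC(=O)c3ccc4c(C5CCCC5)c(-c5ncc(Cl)cn5)n(C)c4c3)CCC2)cc1OCC` differs from compound 2 by methyl(propyl)amino in place of methoxy on a carbonyl carbon. For the measured compounds named here, no measured step bears directly on this change, so compound 3 is expected to stay near compound 2, a step of a 1.2-fold higher number from compound 2 to compound 3 (0.08 log units; within the scatter). Compound 3 is estimated at 2.5 h, between 1.2 h and 5 h.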

Compound 3, half-life: 0.317 h
Compound 3: the middle estimate sits 7.9-fold (0.90 log units) above what was measured; the whole stated range lies above it.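

In this assay, the group on this carbonyl carbon clearly matters: methyl(propyl)amino in place of methoxy gives a 6.6-fold lower number from compound 2 to compound 3 (0.82 log units; beyond the scatter). Against the methyl of compound 1, methyl(propyl)carbamoyl on the saturated chain carbon gives an at least 15-fold lower number from compound 1 to compound 3 (1.19 log units; beyond the scatter), a larger drop than methoxycarbonyl brought. That step is only a bound, as the value of compound 1 is a limit: the limit of > 5 h in this assay, at which 1 of the 3 values shown sits.

On these data alone, it remains open whether a smaller amine such as dimethylamino, a ring amine such as morpholine, or a carboxylic acid on this carbonyl carbon would stay nearer compound 2.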